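Working notes: chloro in place of fluoro

The source may report more compounds than this note shows. Statements on the series, on what has been measured and on what is new or still open speak of the compounds shown alone.

In a functional assay on MCF7 cells (Homo sapiens) for antiproliferative activity, read by sulforhodamine B assay, with a stated time of 48 h (on this read-out lower numbers stand for stronger inhibition and higher numbers for weaker inhibition), compound 1 `O=C(CCCCCCN1C(=O)/C(=N\O)c2ccccc21)NO` gives 790 nM and compound 2 `O=C(CCCCCCN1C(=O)/C(=N\O)c2cc(F)ccc21)NO` gives 1550 nM. Among the measured compounds shown here, these two values lie within the scatter of each other, so compound 2 stands level with the only other measured member of the series.

The next compound, compound 3 `O=C(CCCCCCN1C(=O)/C(=N\O)c2cc(Cl)ccc21)NO`, keeps the shared core and side chain of compound 2 and changes one substituent: chloro in place of fluoro on an aromatic carbon. In words, this is chloro in place of fluoro on an aromatic carbon.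

For the measured compounds named here, only one measured step bears on this change, fluoro in place of hydrogen at the same carbon. That step is a 2.0-fold higher number from compound 1 to compound 2 (0.29 log units; within the scatter), so the one substitution measured at this carbon did not move this assay beyond the scatter. Going by the values given here, no chloro compound has been measured yet, which leaves the estimate resting on this single step and keeps the range wide.

Going by these compounds, no shift beyond the scatter is expected, and the direction remains open. The expected change is a 1.2-fold lower number from compound 2 to compound 3 (0.08 log units; within the scatter). For compound 3 the estimated value is 1300 nM, with an expected range of 550 nM to 3000 nM.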

Compound 3, half-maximal inhibitory concentration: 680 nM
Compound 3: middle estimate off by 1.9-fold (0.28 log units), on the high side; measured number inside the range.
By their numbers in this assay, from the lowest: compounds 3, 1 and 2 (each within the scatter of the next, the first and the last beyond it).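

Working notes, continued: in this assay the exchange of fluoro for chloro on this aromatic carbon gives the first step in the series that lies beyond the scatter (a 2.3-fold lower number from compound 2 to compound 3 (0.36 log units; beyond the scatter)), although it is only modest. Chloro in place of hydrogen on the same carbon stays within the scatter (a 1.2-fold lower number from compound 1 to compound 3 (0.07 log units; within the scatter)), as does fluoro in place of hydrogen, so at this position the two halogens can be told apart from each other, while neither can be told apart from the unsubstituted compound 1. No supporting measurement is available that would account for the separation between compound 2 and compound 3.

Going by these compounds, whether this separation extends beyond the two halogens remains open, and bromo, methoxy or an amine on the same aromatic carbon would show whether other groups fall level with compound 1 or move clear of it. On these data alone, it is also open whether chloro gives the same result on another carbon of this ring, or with a longer chain in place of the present side chain.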